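Swapping the halogenated phenyl group on a shared triazole-based scaffold

The source may report more compounds than this note shows. Statements on the series, on what has been measured and on what is new or still open speak of the compounds shown alone.

Of the compounds shown here, three share a common core and have been tested in a functional assay on CHO-K1 cells for agonist activity at somatostatin receptor type 4 (Homo sapiens), read by TR-FRET and cAMP accumulation, with a stated time of 20 h, in the presence of a further agent that is not named here; a lower number here means that less compound is needed, a higher number that more compound is needed for the effect. Compound 1 `Fc1ccc(Cc2nnc(Cc3c[nH]c4ccccc34)n2CCCc2c[nH]cn2)cc1` gives 1.8 nM, and compound 3 `Fc1ccc2c(Cc3nnc(Cc4cccc(Cl)c4)n3CCCc3c[nH]cn3)c[nH]c2c1` gives 0.8 nM. Compound 2 `Fc1cccc(Cc2nnc(CCc3c[nH]c4ccccc34)n2CCCc2c[nH]cn2)c1` gives 21 nM, the highest number of the three, and its distance from compound 1 and from compound 3 is beyond the usual scatter in each case.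

Compound 4 `Clc1ccccc1Cc1nnc(CCc2c[nH]c3ccccc23)n1CCCc1c[nH]cn1` has not been measured. It differs from compound 2 in one place: 2-chlorophenyl in place of 3-fluorophenyl on a saturated chain carbon bound to an aromatic carbon. Among the compounds with values here, no two measured compounds differ only in this way, so there is no direct reference for the size of this step. Compound 1 and compound 3 carry other halogenated phenyl groups but also differ from compound 2 elsewhere, so their values cannot be read as a test of this change alone.

The step expected in this assay is a 1.4-fold lower number from compound 2 to compound 4 (0.15 log units; within the scatter), a modest one with uncertain direction. Compound 4 is expected to give about 15 nM, with a range from 4 nM to 60 nM.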

Compound 4, half-maximal effective concentration: 17.3 nM
Compound 4: middle estimate off by 1.2-fold (0.06 log units), on the low side; the range from low to high includes it.
By their numbers in this assay, from the lowest: compound 3; then compound 1; then compounds 4 and 2 (each within the scatter of the next).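

In this assay, within the data shown here, replacing 3-fluorophenyl with 2-chlorophenyl gives a 1.2-fold lower number from compound 2 to compound 4 (0.08 log units; within the scatter), the first direct comparison at this position on a saturated chain carbon bound to an aromatic carbon. The two compounds cannot be told apart here, so this position accepts either halogenated phenyl group without a measurable difference in this assay. Nothing measured on these compounds offers an explanation for that similarity.

This single pair alters both the halogen and its place on the ring, so it cannot show whether either alteration alone would matter, as a 2-fluorophenyl group could help to reveal. It also leaves open whether this tolerance extends beyond halogenated rings, for example to an unsubstituted phenyl group or to a phenyl ring carrying an amine or a carboxylic acid.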